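Methyl to chloro on the fused ring of compound 2

The source may hold more compounds than are shown below. What is called first, only, known or untested is meant among the compounds shown, and "the series" means these compounds.

Measured so far:
compound 1 `Cc1cnc(Nc2ccc(S(C)(=O)=O)cc2)nc1Nc1nc2ccc(Cl)cc2s1` — 2500 nM
compound 2 `Cc1ccc2nc(Nc3nc(Nc4ccc(S(C)(=O)=O)cc4)ncc3F)sc2c1` — 9180 nM

In a functional assay on HCT-116 cells (Homo sapiens) for antiproliferative activity, read by MTT assay, with a stated time of 48 h (a higher number here means a weaker inhibitor, a lower number a stronger inhibitor), compound 2 gives 9180 nM, the highest of the two numbers recorded; compound 1 gives 2500 nM, and the gap between the two lies beyond the scatter. Going by the values given here, compound 1 and compound 2 differ in more than one place, so no single step is known between them; their values show only that compound 1 is the stronger inhibitor of the pair.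

Compound 3 `CS(=O)(=O)c1ccc(Nc2ncc(F)c(Nc3nc4ccc(Cl)cc4s3)n2)cc1` is not yet measured. It differs from compound 2 in one place: chloro in place of methyl on an aromatic carbon. Compound 1 also carries chloro at this position, and its lower value in this assay, 2500 nM, is the only hint available. Among the compounds with values here, a step of moderate size toward a lower number is expected, a 2.0-fold lower number from compound 2 to compound 3 (0.31 log units; beyond the scatter), though no measured step supports it directly. Compound 3 is therefore estimated at 4500 nM, within 1500 nM to 13000 nM.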

Compound 3, half-maximal inhibitory concentration: 20700 nM
Compound 3: the middle estimate sits 4.6-fold (0.66 log units) below what was measured; the measured number lies above the stated range.
By their numbers in this assay, from the lowest: compound 1; then compound 2; then compound 3.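

On the carbon of the fused ring, chloro in place of methyl moves the number the wrong way in this assay (a 2.3-fold higher number from compound 2 to compound 3 (0.35 log units; beyond the scatter)), so the chloro of compound 1 does not bring a lower number when the fluoro is present. With chloro held constant on the fused ring, fluoro in place of methyl on the other aromatic carbon also gives a higher number (an 8.3-fold higher number from compound 1 to compound 3 (0.92 log units; beyond the scatter)). Compound 3 is therefore the weakest of the three, and the low number of compound 1 cannot be credited to chloro alone.

Going by these compounds, whether a methoxy group or an amine on the fused-ring carbon would give a lower number than methyl or chloro remains open, as does whether the chloro step holds alongside the methyl of compound 1. Nothing available accounts for either step.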